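A Phenyl Takes the Place of Propyl

The source may hold more compounds than are shown below. What is called first, only, known or untested is meant among the compounds shown, and "the series" means these compounds.

In a functional assay on HUVEC cells (Homo sapiens) for inhibition (a lower number here means a stronger inhibitor, a higher number a weaker inhibitor), compound 1 `COc1cc(/C=C/C(=O)c2cccc(NC(=O)C(C)C)c2)ccc1O` gives 1.44 ug/mL and compound 2 `CCCC(=O)Nc1cccc(C(=O)/C=C/c2ccc(O)c(OC)c2)c1` gives 1.27 ug/mL, two values within the scatter of each other. Compound 3 `COc1cc(/C=C/C(=O)c2cccc(NC(=O)c3ccccc3)c2)ccc1O` has phenyl in place of propyl on a carbonyl carbon, a change counted as phenyl in place of propyl on a carbonyl carbon here. Within the data shown here, the only measured step, a 1.1-fold lower number from compound 1 to compound 2 (0.05 log units; within the scatter), came from swapping propyl for isopropyl and involved no ring, so it offers only a weak guide. The expected step is therefore small and without a firm direction, estimated as a 1.2-fold higher number from compound 2 to compound 3 (0.07 log units; within the scatter) for now. In this assay the estimate for compound 3 is 1.5 ug/mL, with 0.6 ug/mL to 3.8 ug/mL as its expected range.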

Compound 3, half-maximal inhibitory concentration: 0.37 ug/mL
Beside the measured number, compound 3's estimate is 4.1-fold (0.61 log units) above it; measured number outside the range, below it.
By their numbers in this assay, from the lowest: compound 3; then compounds 2 and 1 (each within the scatter of the next).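

In this assay, the exchange between isopropyl and propyl on this carbonyl carbon stayed within the scatter, but a ring there does more: phenyl gives a 3.4-fold lower number from compound 2 to compound 3 (0.54 log units; beyond the scatter) and a 3.9-fold lower number from compound 1 to compound 3 (0.59 log units; beyond the scatter). The position therefore responds to the group it carries, and among these three compounds the benzamido group goes with the lowest number.

On these data alone, whether a longer chain, or a phenyl ring carrying an amine or a carboxylic acid, would do the same on this carbonyl carbon remains open. No measurement available gives a reason for the lower number with phenyl.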